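The source may hold more compounds than are shown below. What is called first, only, known or untested is meant among the compounds shown, and "the series" means these compounds.

Values so far in a functional assay on V79 cells (Cricetulus griseus) for cytotoxicity, read by colony formation; on this read-out lower numbers stand for stronger inhibition and higher numbers for weaker inhibition:
compound 1 `NCC1CCN(c2c(F)cc3c(=O)c(C(=O)O)cn(C4CC4)c3c2F)C1` gives 11 ug/mL
compound 2 `NCC1CCN(c2c(F)cc3c(=O)c(C(=O)O)cn(C4CC4)c3c2Cl)C1` gives 8 ug/mL
compound 3 `NCC1CCN(c2c(F)cc3c(=O)c(C(=O)O)cn(C4CC4)c3c2C(F)(F)F)C1` gives 38 ug/mL

Among the measured compounds shown here, compound 3 gives 38 ug/mL as the highest of the three numbers, which makes it the weakest of the set in this assay so far. Both of its gaps are modest: a 3.5-fold higher number from compound 1 to compound 3 (0.54 log units; beyond the scatter) and a 4.8-fold higher number from compound 2 to compound 3 (0.68 log units; beyond the scatter) are the two steps that reach it. The remaining pair does not separate, with a 1.4-fold lower number from compound 1 to compound 2 (0.14 log units; within the scatter) as the measured step.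

Next comes compound 4 `CNCC1(C)CCN(c2c(F)cc3c(=O)c(C(=O)O)cn(C4CC4)c3c2C(F)(F)F)C1` which keeps the trifluoromethyl group. The change 3-methyl-3-((methylamino)methyl)pyrrolidin-1-yl in place of 3-(aminomethyl)pyrrolidin-1-yl on an aromatic carbon puts 3-methyl-3-((methylamino)methyl)pyrrolidin-1-yl in place of 3-(aminomethyl)pyrrolidin-1-yl on an aromatic carbon, ortho to a fluoro group and to a trifluoromethyl group.

For the measured compounds named here, no measured step touches this group, since all three swap fluoro, chloro and trifluoromethyl. Going by the values given here, the direction therefore stays open, and the data hold no direct precedent. The largest shift seen so far, a 4.8-fold higher number from compound 2 to compound 3 (0.68 log units; beyond the scatter) as a guide to size only, sets a wide range.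

No step beyond the scatter is expected, the estimated change being a 1.1-fold lower number from compound 3 to compound 4 (0.04 log units; within the scatter) in this assay as the central case. For compound 4 the estimated value is 35 ug/mL with an expected range from 13 ug/mL to 95 ug/mL around it.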

Compound 4, half-maximal inhibitory concentration: 230 ug/mL
For compound 4 the middle estimate is 6.6-fold (0.82 log units) below the measured one; the whole stated range lies below it.
By their numbers in this assay, from the lowest: compounds 2 and 1 (each within the scatter of the next); then compound 3; then compound 4.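

In this assay, among the compounds shown here, the first change at the position carrying the pyrrolidine side chain, on the aromatic carbon ortho to a fluoro group and to a trifluoromethyl group, gives a 6.1-fold higher number from compound 3 to compound 4 (0.78 log units; beyond the scatter) and moves the read-out toward weaker inhibition. This position therefore responds beyond the scatter, as the neighbouring position did when trifluoromethyl replaced fluoro or chloro, so the series can no longer be read through that one substituent alone. The change from 3-(aminomethyl)pyrrolidin-1-yl to 3-methyl-3-((methylamino)methyl)pyrrolidin-1-yl brings in the ring methyl and the methyl on the amine together, and no measurement at hand gives a reason for the shift.

The compounds shown leave open which of the two methyl groups carries the step, and whether the same side chain behaves alike with fluoro or chloro in place of trifluoromethyl. Also open, from the compounds shown here alone, is how the read-out would respond to a longer aminoethyl chain, or to a hydroxyl group in place of the amine, at this position.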